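A few compounds are considered here, and "the series" means these few. Any claim that something is new, unique, unknown or untested is made for them only; others in the source may bear on it.

The set comprises three measured compounds and one awaiting measurement. In a functional assay on NCI-H522 cells (Homo sapiens) for inhibition, read by sulforhodamine B assay, with a stated time of 48 h (on this read-out lower numbers stand for stronger inhibition of growth and higher numbers for weaker inhibition of growth), compound 1 `O=C(Nc1cccc(-n2cc(-c3ccncc3)c(-c3ccc(Cl)c(O)c3)n2)c1)Nc1cccc(C(F)(F)F)c1` gives 1460 nM, compound 2 `COc1cc(-c2nn(-c3cccc(NC(=O)Nc4cc(C(F)(F)F)cc(C(F)(F)F)c4)c3)cc2-c2ccncc2)ccc1Cl` gives 623 nM, and compound 3 `COc1cc(-c2nn(-c3cccc(NC(=O)Nc4cccc(C(F)(F)F)c4)c3)cc2-c2ccncc2)ccc1Cl` gives 714 nM. Compound 2 sits at the low end of these numbers; compound 3 lies within the scatter of it, as the step of a 1.1-fold higher number from compound 2 to compound 3 (0.06 log units; within the scatter) shows, while compound 1 lies further off, beyond the scatter.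

Compound 4 `O=C(Nc1cccc(-n2cc(-c3ccncc3)c(-c3ccc(Cl)c(O)c3)n2)c1)Nc1cc(C(F)(F)F)cc(C(F)(F)F)c1` differs from compound 2 in one place: hydrogen in place of methyl on an oxygen on an aromatic ring, that is, methoxy to hydroxy, or 4-chloro-3-methoxyphenyl to 4-chloro-3-hydroxyphenyl. For the measured compounds named here, one measured step bears on this change, and it runs the other way: a 2.0-fold lower number from compound 1 to compound 3 (0.31 log units; beyond the scatter), where methyl replaced hydrogen on that same oxygen. The step of a 1.1-fold higher number from compound 2 to compound 3 (0.06 log units; within the scatter) touches only the trifluoromethyl and says nothing about the oxygen, but it does show that compound 2 and compound 3 are comparable starting points. Reversing the methylation on compound 2 is therefore expected to give a higher number, of about the size seen between compound 1 and compound 3. The expected step reads a 2.0-fold higher number from compound 2 to compound 4 (0.30 log units; within the scatter). For compound 4 in this assay the estimate is 1250 nM, with a range from 700 nM to 2300 nM.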

Compound 4, concentration for 50% growth inhibition: 724 nM
Estimate against measurement, compound 4: 1.7-fold (0.24 log units) above; the range from low to high includes it.
By their numbers in this assay, from the lowest: compounds 2, 3, 4 and 1 (each within the scatter of the next, the first and the last beyond it).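

In this assay, with a second trifluoromethyl present, the change from methoxy to hydroxy reads a 1.2-fold higher number from compound 2 to compound 4 (0.07 log units; within the scatter), so on this core the change stays within the scatter, yet the two readings of it cannot be told apart: the same change on two cores in this assay, a 2.0-fold lower number (0.31 log units; beyond the scatter) from compound 1 to compound 3 and a 1.2-fold lower number (0.07 log units; within the scatter) from compound 4 to compound 2, 1.8-fold (0.25 log units) apart, within the scatter of two such steps. The trifluoromethyl change can now also be read on the hydroxy compounds, as a 2.0-fold lower number from compound 1 to compound 4 (0.30 log units; within the scatter), and this too lies within the scatter and agrees with its reading on the methoxy compounds: the same change on two cores in this assay, a 1.1-fold higher number (0.06 log units; within the scatter) from compound 2 to compound 3 and a 2.0-fold higher number (0.30 log units; within the scatter) from compound 4 to compound 1, 1.8-fold (0.25 log units) apart, within the scatter of two such steps. Of the four single changes now available, only a 2.0-fold lower number from compound 1 to compound 3 (0.31 log units; beyond the scatter) lies beyond the scatter, and even that step lies only just past it, so these compounds show no clear preference at this oxygen.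

What the compounds shown leave open is whether a group larger than methyl on this oxygen, such as ethyl or a longer chain, or an amine in place of the hydroxy, would move the number beyond the scatter on either core. They also leave open whether chlorine or a nitrile in place of the second trifluoromethyl would do so.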